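The compounds below may be only part of what the source reports. "The series", "measured", "known", "first", "only" and "open" are said of these compounds alone.

Compounds measured so far:
compound 1, `CCCn1c(=O)[nH]c2nc(-c3ccc(S(=O)(=O)N4CCN(C)CC4)cc3)[nH]c2c1=O`, 334 nM
compound 2, `CCCn1c(=O)[nH]c2nc(-c3ccc(S(=O)(=O)N4CCN(c5ccccc5Br)CC4)cc3)[nH]c2c1=O`, > 1000 nM
compound 3, `CCCn1c(=O)[nH]c2nc(-c3ccc(S(=O)(=O)N4CCN(Cc5ccc(Br)c(F)c5)CC4)cc3)[nH]c2c1=O`, 326 nM

In an assay on CHO cells for displacement of a labelled ligand from adenosine receptor A1 (Homo sapiens), read by scintillation counting, with a stated time of 90 min, in the presence of a further agent that is not named here (on this read-out higher numbers stand for weaker inhibition and lower numbers for stronger inhibition), compound 3 gives the lowest of the two numbers shown; compound 1 sits within the scatter of it, a 1.0-fold lower number from compound 1 to compound 3 (0.01 log units; within the scatter). Compound 2 gives only a limit of the assay, not a number (the limit of > 1000 nM in this assay, at which 1 of the 3 values shown sits). Compound 4, `CCCn1c(=O)[nH]c2nc(-c3ccc(S(=O)(=O)N4CCN(C(C)c5ccccc5)CC4)cc3)[nH]c2c1=O`, is not yet measured. It differs from compound 3 in one place: 1-phenylethyl in place of 4-bromo-3-fluorobenzyl on an amine nitrogen in a ring. Within the data shown here, two measured steps bear on this. The step of a 1.0-fold lower number from compound 1 to compound 3 (0.01 log units; within the scatter) shows that placing an aromatic ring on the chain carbon bound to the ring nitrogen leaves the number unchanged, whereas an at least 3.0-fold lower number from compound 2 to compound 3 (0.48 log units; beyond the scatter) shows that an aromatic ring directly on that nitrogen worsens it. Compound 4 keeps the ring on a chain carbon, so no step beyond the scatter is expected, a 1.0-fold higher number from compound 3 to compound 4 (0.02 log units; within the scatter). Compound 4 is therefore expected to give about 340 nM, between 150 nM and 800 nM.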

Compound 4, inhibition constant: >= 1000 nM
Compound 4 ended at the assay's limit; the forecaster's own chance of this, stated with the estimate: 10%; at least 2.9-fold (0.46 log units) between middle value and limit.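

Compound 4 gives only a limit in this assay, not a number. An aromatic ring on a chain carbon bound to the ring nitrogen therefore does not by itself hold the number down, as the steps show: an at least 3.0-fold higher number from compound 3 to compound 4 (0.48 log units; beyond the scatter), and an at least 2.9-fold higher number from compound 1 to compound 4 (0.47 log units; beyond the scatter). The step between compound 2 and compound 4 cannot be read: both ends are limits.

Going by these compounds, this change removes bromine and fluorine and also swaps the chain, so which of these matters stays open. A plain benzyl group on that nitrogen would help to separate the two.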